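Anilide substituent swap: compound 2 to compound 3

A few compounds are considered here, and "the series" means these few. Any claim that something is new, unique, unknown or untested is made for them only; others in the source may bear on it.

Compound 1 `O=C(CCC(=O)OCCCCCCSc1ccc([N+](=O)[O-])c2nonc12)Nc1ccccc1` and compound 2 `O=C(CCC(=O)OCCCCCCSc1ccc([N+](=O)[O-])c2nonc12)Nc1ccccc1Cl` share one core and differ only in the anilide ring. In a functional assay on A549 cells (Homo sapiens) for inhibition, read by MTT assay, with a stated time of 72 h (a higher number here means a weaker inhibitor, a lower number a stronger inhibitor), compound 1 gives 1960 nM, and compound 2 gives 2750 nM. Among the measured compounds shown here, the step of a 1.4-fold higher number from compound 1 to compound 2 (0.15 log units; within the scatter) lies within the scatter; on the numbers so far compound 2 holds the highest of the two values, with compound 1 nearest and within the scatter of it.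

Compound 3 `COc1ccccc1NC(=O)CCC(=O)OCCCCCCSc1ccc([N+](=O)[O-])c2nonc12` is not yet measured. It differs from compound 2 by methoxy in place of chloro on an aromatic carbon. For the measured compounds named here, the only measured step at this position is a 1.4-fold higher number from compound 1 to compound 2 (0.15 log units; within the scatter), which stayed within the scatter; no measured step replaces a chloro with a methoxy here. On that basis no step beyond the scatter is expected from compound 2 to compound 3, the estimated step being a 1.1-fold lower number from compound 2 to compound 3 (0.06 log units; within the scatter). Compound 3 is expected to give 2400 nM in this assay, with a range from 900 nM to 6500 nM.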

Compound 3, half-maximal inhibitory concentration: 1870 nM
For compound 3 the middle estimate is 1.3-fold (0.11 log units) above the measured one; low and high end bracket the measured number.
By their numbers in this assay, from the lowest: compounds 3, 1 and 2 (each within the scatter of the next).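

In this assay, methoxy in place of chloro gives a 1.5-fold lower number from compound 2 to compound 3 (0.17 log units; within the scatter), and methoxy in place of hydrogen gives a 1.0-fold lower number from compound 1 to compound 3 (0.02 log units; within the scatter). Hydrogen, chloro and methoxy on this aromatic carbon, ortho to a large group, now all lie within the scatter of one another, so the flat reading extends to a group that brings a hydrogen-bond acceptor by the count, which the chloro step alone could not show. No measurement shown here bears on why these values lie so close.

The compounds shown leave open whether an amine or a carboxylic acid on this carbon would give a step beyond the scatter. They also leave open whether the flat reading would hold with a longer chain joining the anilide to the shared core.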